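The compounds below may be only part of what the source reports. "The series", "measured", "known", "first", "only" and "open" are said of these compounds alone.

Measured so far in a functional assay on the whole organism (strain Sprague-Dawley) for inhibition, with Rattus norvegicus as the target; on this read-out lower numbers stand for an effect already at smaller amounts and higher numbers for an effect only at larger amounts of compound:
compound 1 `CCc1cccc2c(=O)c(-c3nn[nH]n3)c[nH]c12`: 0.312 mg/kg
compound 2 `COc1ccc(OC)c2c(=O)c(-c3nn[nH]n3)c[nH]c12`: 1.25 mg/kg
compound 3 `CSc1cccc2c(=O)c(-c3nn[nH]n3)c[nH]c12`: 10 mg/kg

Compound 3 stands highest of the three in this assay; compound 2 comes nearest with its value of 1.25 mg/kg, and compound 1 lies furthest away with 0.312 mg/kg. Compound 4 `O=c1c(-c2nn[nH]n2)c[nH]c2c(Cl)cccc12` differs from compound 3 in one place: chloro in place of methylsulfanyl on an aromatic carbon. Among the compounds with values here, only one measured step touches this position: a 32-fold higher number from compound 1 to compound 3 (1.51 log units; beyond the scatter), which shows that this position can move the read-out strongly. Within the data shown here, no measured pair shows chloro itself, so the direction is uncertain. Since methylsulfanyl carries the highest number of the series and chloro is a smaller group, a lower number than that of compound 3 is expected, though well short of compound 1. The expected step is a 4.0-fold lower number from compound 3 to compound 4 (0.60 log units; beyond the scatter); compound 4 is estimated at 2.5 mg/kg, within 0.6 mg/kg to 10 mg/kg.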

Compound 4, minimum effective dose: 0.078 mg/kg
For compound 4 the middle estimate is 32-fold (1.51 log units) above the measured one; the whole stated range lies above it.
By their numbers in this assay, from the lowest: compound 4; then compound 1; then compound 2; then compound 3.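

Chloro in place of methylsulfanyl on this aromatic carbon gives a 130-fold lower number from compound 3 to compound 4 (2.11 log units; beyond the scatter) in this assay, so the position reaches well below the values of the earlier compounds. The high number of compound 3 is therefore not the only strong effect at this place, since chloro also improves on ethyl, with a 4.0-fold lower number from compound 1 to compound 4 (0.60 log units; beyond the scatter). Nothing available explains this order of the three groups.

On these data alone, whether bromo or an amine on this carbon would follow chloro or methylsulfanyl remains open. Also open, as far as these compounds go, is how far a longer chain would move the number from that of ethyl.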